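The compounds below may be only part of what the source reports. "The series", "measured", "known", "first", "only" and "open" are said of these compounds alone.

- Compound 1 `O=C(Nc1ccc(-c2cscn2)cc1)C1CCN(Cc2ccc(F)c(F)c2)CC1`: 19000 nM
- Compound 2 `O=C(Nc1ccc(-c2cscn2)cc1)C1CCCN(C(=O)c2ccc(F)c(F)c2)C1`: > 20000 nM

In a functional assay on A-375 cells (Homo sapiens) for activation, with a stated time of 3 days (a lower number here means that less compound is needed, a higher number that more compound is needed for the effect), compound 2 stands at > 20000 nM, which is a limit of the assay and not a number. Compound 3 `O=C(Nc1ccc(-c2cscn2)cc1)C1CCCN(Cc2cc(F)cc(F)c2)C1` carries 3,5-difluorobenzyl in place of (3,4-difluorophenyl)carbonyl on an amine nitrogen in a ring. For the measured compounds named here, no measured pair shows the size of this change. Going by the values given here, the only measured number is that of compound 1, at 19000 nM, so only a small move toward lower numbers in this assay is expected, perhaps none beyond the scatter. The estimated step is an at least 1.3-fold lower number from compound 2 to compound 3 (0.12 log units; that floor lies within the scatter). Compound 3 is expected at 15000 nM, within an estimated range of 6000 nM to 20000 nM.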

Compound 3, half-maximal effective concentration: 1500 nM
Compound 3: middle estimate off by 10-fold (1.00 log units), on the high side; the whole stated range lies above it.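

In this assay, replacing (3,4-difluorophenyl)carbonyl with 3,5-difluorobenzyl on the amine nitrogen gives an at least 13-fold lower number from compound 2 to compound 3 (1.12 log units; beyond the scatter), so the group at this position can strongly change the concentration needed. The true step may be larger, because the value of compound 2 is a limit of the assay and not a number: the limit of > 20000 nM in this assay, at which 1 of the 3 values shown sits. The two groups differ both in the carbonyl and in the placing of the fluorines, and the compounds shown cannot separate these two changes. On these data alone, how a longer chain or a methoxy-substituted benzyl would read at this position also remains open.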